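Swapping a Ring Substituent: Chloro to Cyano

This account rests on a few compounds, and the source may have more. Where it says the series, first, only, none or still open, it means among the compounds named here.

Compound 1, `Cc1cccc(CN2CC=C(CCC(=O)NO)C2=O)c1`, gives 3330 nM in a functional assay on ACHN cells (Homo sapiens) for inhibition, read by sulforhodamine B assay; on this read-out higher numbers stand for weaker inhibition of growth and lower numbers for stronger inhibition of growth.
Compound 2, `O=C(CCC1=CCN(Cc2cccc(Br)c2)C1=O)NO`, gives 3330 nM in this assay.
Compound 3, `O=C(CCC1=CCN(Cc2cccc(Cl)c2)C1=O)NO`, gives 3330 nM in this assay.

Compound 3 stands level with compounds 1 and 2: the step of no change at the digits printed from compound 1 to compound 3 (within the scatter) and the step of no change at the digits printed from compound 2 to compound 3 (within the scatter) both lie within the scatter, as does no change at the digits printed from compound 1 to compound 2 (within the scatter). Each of these three steps exchanges one group on an aromatic carbon of the six-membered aromatic ring of carbon only — methyl, bromo, chloro — and none of them shifted growth inhibition in this assay.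

Compound 4, `N#Cc1cccc(CN2CC=C(CCC(=O)NO)C2=O)c1`, has not yet been measured. It differs from compound 3 by cyano in place of chloro on an aromatic carbon: chloro leaves and cyano enters, on an aromatic carbon of a six-membered aromatic ring of carbon only, meta to a large group.

All three measured steps bear on this change, since each alters the group at this same place, and all three stayed within the scatter. Cyano has not been tried here, so there is no direct precedent, but among compounds 1, 2 and 3 the read-out has shown no sensitivity to what sits there. I therefore expect no step beyond the scatter, no change at the digits printed from compound 3 to compound 4 (within the scatter). Compound 4 is estimated at 3330 nM, with a range from 1500 nM to 7500 nM.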

Compound 4, concentration for 50% growth inhibition: 7750 nM
Estimate against measurement, compound 4: 2.3-fold (0.37 log units) below; measured number outside the range, above it.
By their numbers in this assay, from the lowest: compounds 1, 2 and 3 (each within the scatter of the next); then compound 4.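

The place on the aromatic ring is not as indifferent to its substituent as the methyl, bromo and chloro compounds alone suggested. In this assay, cyano in place of chloro gives a clear shift (a 2.3-fold higher number from compound 3 to compound 4 (0.37 log units; beyond the scatter)), and the comparisons with the other two groups, cyano in place of bromo (a 2.3-fold higher number from compound 2 to compound 4 (0.37 log units; beyond the scatter)) and cyano in place of methyl (a 2.3-fold higher number from compound 1 to compound 4 (0.37 log units; beyond the scatter)), agree with it: the steps are modest but beyond the scatter, and all point towards weaker inhibition of growth, so of the four groups shown, cyano alone separates from the rest. Nothing available here explains why cyano parts from the other three groups.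

The compounds shown leave open whether other groups on this aromatic carbon, such as an amine, a carboxylic acid or a methoxy group, would stay level with compounds 1, 2 and 3 or move away from them, and in which direction. They also leave open whether cyano in place of chloro would give a similar step on a core with a longer chain.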